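An Estimate for Compound 4 Without a Direct Anchor

The source may hold more compounds than are shown below. What is called first, only, known or untested is meant among the compounds shown, and "the series" means these compounds.

Among the compounds with values here, three compounds built on a shared core were taken into a functional assay on HeLa cells (Homo sapiens) for inhibition, read by MTT assay, with a stated time of 48 h (a higher number here means a weaker inhibitor, a lower number a stronger inhibitor), and only two returned numbers. Compound 1 `CS(=O)(=O)Nc1ccc(-n2cc(COc3ccccc3Cl)nn2)cc1Oc1ccccc1` gave 38600 nM in this assay and compound 2 `CS(=O)(=O)Nc1ccc(-n2cc(-c3ccccc3)nn2)cc1Oc1ccccc1` gave 21900 nM there. Within the data shown here, the one measured step between them, a 1.8-fold lower number from compound 1 to compound 2 (0.25 log units; within the scatter), swaps one large group for another and moves the reading by no more than repeat measurements would. Compound 3 `CS(=O)(=O)Nc1ccc(-n2cc(OCc3ccccc3)nn2)cc1Oc1ccccc1` has no place on this scale: its entry reads "not determined" (no result reported), so it offers no starting number.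

Compound 4 `Cc1cc(OCc2cn(-c3ccc(NS(C)(=O)=O)c(Oc4ccccc4)c3)nn2)ccc1Cl` differs from compound 3 by (4-chloro-3-methylphenoxy)methyl in place of benzyloxy on an aromatic carbon, with (4-chloro-3-methylphenoxy)methyl in place of benzyloxy on an aromatic carbon of a five-membered aromatic ring with 3 nitrogen. Among the measured compounds shown here, no measured step covers this exchange. For the measured compounds named here, the nearest relative is compound 1, whose (2-chlorophenoxy)methyl group also appears in the one measured step and whose reading of 38600 nM serves as the anchor. That single step stayed within the scatter, so no shift beyond the scatter is expected from that level, in either direction, though one pair is thin evidence. For compound 4 the estimated value in this assay is 30000 nM with an expected range from 12000 nM to 75000 nM as a deliberately wide estimate.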

Compound 4, half-maximal inhibitory concentration: 7900 nM
Compound 4: middle estimate off by 3.8-fold (0.58 log units), on the high side; measured number outside the range, below it.
By their numbers in this assay, from the lowest: compound 4; then compounds 2 and 1 (each within the scatter of the next).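

In this assay, within the data shown here, the group on this aromatic carbon of the five-membered aromatic ring with 3 nitrogen now moves the reading beyond the scatter, which the one earlier step did not show: (4-chloro-3-methylphenoxy)methyl in place of phenyl gives a 2.8-fold lower number from compound 2 to compound 4 (0.44 log units; beyond the scatter) and so separates this group from a plain phenyl. The link to the ring stays the same in the second comparison, where 4-chloro-3-methylphenyl in place of 2-chlorophenyl on an oxygen on a saturated carbon gives a 4.9-fold lower number from compound 1 to compound 4 (0.69 log units; beyond the scatter), so the reading here depends on the ring carried on that oxygen and not only on the presence of a phenoxymethyl-type group. Nothing available accounts for either shift, and no supporting data bear on the result.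

The compounds shown change the chlorine and the methyl together, so they leave open what each contributes on its own to the step from the 2-chlorophenyl group. Going by these compounds, whether a methoxy group or an amine on that same ring would give a lower or a higher number also remains open.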